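The source may report more compounds than this note shows. Statements on the series, on what has been measured and on what is new or still open speak of the compounds shown alone.

Measured so far:
Compound 1, `CNC(=O)CCCCCCCn1nc(-c2ccc3oc(N)nc3c2)c2c(N)ncnc21`: 99.1%
Compound 2, `Nc1ncnc2c1c(-c1cnc3[nH]ccc3c1)nn2CCCCCCCCCC(=O)NO`: 98.3%

Both were tested in an assay on isolated protein for inhibition of protein deacetylase HDAC6 (Homo sapiens), with a stated time of 15 min, tested at 1 uM; on this read-out lower numbers stand for less inhibition and higher numbers for more inhibition at the one concentration tested (going by the name of the read-out). Compound 1 gives the higher of the two numbers, with compound 2 a small distance lower, a gap that lies within the usual scatter of this kind of measurement, so the two cannot be told apart on these figures. The unmeasured compound 3, `Nc1nc2cc(-c3nn(CCCCCCCCC(=O)NO)c4ncnc(N)c34)ccc2o1`, differs from compound 1 in one place: (hydroxycarbamoyl)methyl in place of methylcarbamoyl on a saturated chain carbon, seven bonds along the chain from an aromatic nitrogen. Going by the values given here, no step between measured compounds is available to calibrate this change; the only guide is that compound 2, which also carries a hydroxycarbamoyl group, reaches 98.3% in this assay. Compound 1 already sits close to the ceiling of the read-out, so little room for a rise remains, and a drop beyond the scatter is not expected. Compound 3 is therefore estimated at 98%, between 92% and 100%, a step of a number 1.1 percentage points lower from compound 1 to compound 3 (within the scatter) that is expected to stay within the scatter.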

Compound 3, a percentage reported as inhibition, at one concentration (the size of the read-out at that concentration, not a potency): 99%
The estimate for compound 3 lay 1 percentage points below the measured number; the measured number falls inside the stated range.
By their numbers in this assay, from the lowest: compounds 2, 3 and 1 (each within the scatter of the next).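

In this assay the exchange of methylcarbamoyl for (hydroxycarbamoyl)methyl on a saturated chain carbon, seven bonds along the chain from an aromatic nitrogen, gives a number 0.1 percentage points lower from compound 1 to compound 3 (within the scatter) and so leaves the two chain ends indistinguishable at this one concentration. Going by these compounds alone, this is the first direct comparison of these two groups at this place on the shared core, yet both numbers lie near the top of the scale, where any real difference in potency could stay hidden. Nothing available here offers an explanation for the result.

From the compounds shown here alone, whether the two compounds would separate at lower concentrations remains open. So does how a carboxylic acid, a primary amine or a longer chain ending in the same hydroxycarbamoyl group would read at this place.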